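From phenyl to 4-methoxyphenyl in compound 1

A few compounds are considered here, and "the series" means these few. Any claim that something is new, unique, unknown or untested is made for them only; others in the source may bear on it.

Going by the values given here, in a functional assay on DWD cells (Homo sapiens) for inhibition, read by sulforhodamine B assay (on this read-out lower numbers stand for stronger inhibition of growth and higher numbers for weaker inhibition of growth), compound 1 (`c1ccc(-c2ccc(-c3ccc(-c4nc5ccccc5[nH]4)cc3)cc2)cc1`) gives 100000 nM, the highest of the three numbers so far. Compound 2 (`Cc1ccc2[nH]c(-c3ccc(-c4ccc(-c5cccc(Cl)c5)cc4)cc3)nc2c1`) gives 2510 nM, and compound 3 (`COc1ccc(-c2ccc(-c3ccc(-c4nc5cc(C)ccc5[nH]4)cc3)cc2)cc1OC`) gives 1720 nM.

Compound 4 (`COc1ccc(-c2ccc(-c3ccc(-c4nc5ccccc5[nH]4)cc3)cc2)cc1`) follows from compound 1 by methoxy in place of hydrogen on an aromatic carbon, para to a large group.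

Among the compounds with values here, the only measured single-place change is a 1.5-fold lower number from compound 2 to compound 3 (0.16 log units; within the scatter), which swaps 3-chlorophenyl for 3,4-dimethoxyphenyl and lies within the scatter. It does not test adding a group to a bare phenyl. Compound 2 and compound 3 each differ from compound 1 in more than one place, so the data cannot divide the gap between those places. Compound 3 at 1720 nM nevertheless suggests that only part of that gap should appear here.

The expected change is a 6.7-fold lower number from compound 1 to compound 4 (0.82 log units; beyond the scatter), towards stronger inhibition of growth and beyond the scatter. For compound 4 the estimated value is 15000 nM, with an expected range of 3000 nM to 60000 nM.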

Compound 4, concentration for 50% growth inhibition: 100000 nM
Estimate against measurement, compound 4: 6.7-fold (0.82 log units) below, outside the stated range (above it).
By their numbers in this assay, from the lowest: compounds 3 and 2 (each within the scatter of the next); then compounds 1 and 4 (each within the scatter of the next).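

In this assay, methoxy in place of hydrogen on an aromatic carbon, para to a large group, gives no change at the digits printed from compound 1 to compound 4 (within the scatter) as its direct result. Going by these compounds alone, this is the first reading of a group added to the bare phenyl of compound 1: phenyl to 4-methoxyphenyl alone does not move the number on this core. The earlier step between compound 2 and compound 3 could not show this, as it replaced one substituted phenyl with another.

No measured information bears on why the number holds.

Still open, as far as these compounds go, is whether an amine or a carboxylic acid at this same position would read as methoxy does. Also open, from the compounds shown here alone, is what the methyl group on the core of compound 2 and compound 3, which compound 4 lacks, contributes to their numbers.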